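Swapping 3-hydroxyphenyl for cyclohexyl on the shared core

This account rests on a few compounds, and the source may have more. Where it says the series, first, only, none or still open, it means among the compounds named here.

Values measured in a functional assay on MCF7 cells (Homo sapiens) for inhibition, read by MTT assay, with a stated time of 48 h (on this read-out lower numbers stand for stronger inhibition and higher numbers for weaker inhibition), are:
- compound 1 `Brc1ccc2[nH]cc(C(c3ccccc3)c3c[nH]c4ccc(Br)cc34)c2c1` gives 5500 nM
- compound 2 `Oc1cccc(C(c2c[nH]c3ccc(Br)cc23)c2c[nH]c3ccc(Br)cc23)c1` gives 2800 nM
- compound 3 `COc1ccc(C(c2c[nH]c3ccc(Br)cc23)c2c[nH]c3ccc(Br)cc23)cc1` gives 2300 nM

Compound 2 lies within the scatter of both other compounds. Hydroxy in place of hydrogen on an aromatic carbon gave a 2.0-fold lower number from compound 1 to compound 2 (0.29 log units; within the scatter), while the swap to compound 3 gave a 1.2-fold lower number from compound 2 to compound 3 (0.09 log units; within the scatter). Only the methoxy change clears the scatter, and modestly, as a 2.4-fold lower number from compound 1 to compound 3 (0.38 log units; beyond the scatter) shows.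

The next compound is compound 4 `Brc1ccc2[nH]cc(C(c3c[nH]c4ccc(Br)cc34)C3CCCCC3)c2c1`, still unmeasured in this assay. Its difference from compound 2 is cyclohexyl in place of 3-hydroxyphenyl on a saturated chain carbon bound to two aromatic carbons. This change falls at the same carbon as the swap from compound 2 to compound 3, which makes that step the closest guide. Among the compounds with values here, that swap kept an aromatic ring, however, and no measured compound carries a non-aromatic ring at this carbon, so the data offer no direct test and no firm direction. All three measured steps are small, so only a small change is expected, with none beyond the scatter. The expected change is a 1.1-fold higher number from compound 2 to compound 4 (0.03 log units; within the scatter), though a larger move remains possible. For compound 4 the estimated value is 3000 nM, with an expected range from 1000 nM to 9000 nM.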

Compound 4, half-maximal inhibitory concentration: 4100 nM
For compound 4 the middle estimate is 1.4-fold (0.14 log units) below the measured one; the range from low to high includes it.
By their numbers in this assay, from the lowest: compounds 3, 2, 4 and 1 (each within the scatter of the next, the first and the last beyond it).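

In this assay, within the data shown here, compound 4 is the first reading of a non-aromatic ring at this saturated chain carbon bound to two aromatic carbons, and cyclohexyl cannot be told apart from any of the three aromatic groups measured there: the steps are a 1.5-fold higher number from compound 2 to compound 4 (0.17 log units; within the scatter), a 1.8-fold higher number from compound 3 to compound 4 (0.25 log units; within the scatter) and a 1.3-fold lower number from compound 1 to compound 4 (0.13 log units; within the scatter). An aromatic ring at this carbon is therefore not required for a value in this range, and neither are the hydrogen-bond donor and acceptor that leave with 3-hydroxyphenyl, since all three steps stay within the scatter. No evidence is available that bears on why these values lie so close together.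

The compounds shown leave open whether a group of another kind at this carbon, such as an aminomethyl group, a carboxylic acid or a longer chain such as n-hexyl, would give a step beyond the scatter. They also leave open whether cyclohexyl would behave the same way with chlorine in place of the two bromines on the shared core.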